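Cytotoxicity of three arylthio and arylseleno amides, one more

A few compounds are considered here, and "the series" means these few. Any claim that something is new, unique, unknown or untested is made for them only; others in the source may bear on it.

Measured compounds:
compound 1, `CCCC(=O)OCSc1ccccc1C(=O)NCCCNC(C)=O`, 21.1 uM
compound 2, `CCCC(=O)OCSc1ccccc1C(=O)Nc1ccccc1C(N)=O`, 50.1 uM
compound 3, `CCCC(=O)OC[Se]c1ccccc1C(=O)NCCC(N)=O`, 10.5 uM

In an ADME assay on CEM-SS cells (Homo sapiens) for cytotoxicity, read by XTT assay, with a stated time of 6 days (a lower number here means that less compound is tolerated, a higher number that more compound is tolerated), compound 1 holds the second highest of the three numbers. Compound 3 lies nearest to it, within the scatter, so the two cannot be told apart; compound 2 lies furthest, with a higher number beyond the scatter. Compound 4, `CCCC(=O)OCSc1ccccc1C(=O)NCC(=O)N(C)C`, has not yet been measured. It differs from compound 1 in one place: dimethylcarbamoyl in place of 2-acetamidoethyl on a saturated chain carbon bound to an amide-type nitrogen. Among the compounds with values here, no measured pair shows a step of this kind, so the size of the step from compound 1 to compound 4 in this assay is open. The writer expects a step of a 1.1-fold lower number from compound 1 to compound 4 (0.02 log units; within the scatter), that is, no change beyond the scatter. For compound 4 the estimated value in this assay is 20 uM, between 8 uM and 50 uM.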

Compound 4, half-maximal toxic concentration: 38.3 uM
Beside the measured number, compound 4's estimate is 1.9-fold (0.28 log units) below it; measured number inside the range.
By their numbers in this assay, from the lowest: compounds 3, 1, 4 and 2 (each within the scatter of the next, the first and the last beyond it).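

In this assay, this place on a saturated chain carbon bound to an amide-type nitrogen gives its first readable step, a 1.8-fold higher number from compound 1 to compound 4 (0.26 log units; within the scatter), which lies within the scatter. Compound 1 and compound 4 therefore cannot be told apart, although dimethylcarbamoyl replaces 2-acetamidoethyl and the count of hydrogen-bond donors in the group falls. No supporting data explain this result. The compounds shown leave open whether an amine, a carboxylic acid or a longer chain at this place would give a step beyond the scatter.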